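The source may hold more compounds than are shown below. What is called first, only, known or untested is meant among the compounds shown, and "the series" means these compounds.

In a functional assay on HepG2 cells (Homo sapiens) for cytotoxicity, read by MTT assay, with a stated time of 72 h (on this read-out higher numbers stand for weaker inhibition and lower numbers for stronger inhibition), compound 1 `COc1cc2ncnc(Nc3ccc(F)c(Cl)c3)c2cc1NC(=O)N/N=C/c1ccc([N+](=O)[O-])cc1` gives 34100 nM, and compound 2 `COc1cc2ncnc(Nc3ccc(F)c(Cl)c3)c2cc1NC(=O)N/N=C/c1ccc(F)cc1Cl` gives 29200 nM. These two numbers lie within the usual scatter of each other, so compound 2 stands level with compound 1 and the pair cannot be ranked. Compound 3 `COc1cc2ncnc(Nc3ccc(F)c(Cl)c3)c2cc1NC(=O)N/N=C/c1cccc(Cl)c1Cl` keeps the shared core, and the change comes on a carbon with a double bond to nitrogen, where 2,3-dichlorophenyl takes the place of 2-chloro-4-fluorophenyl (2,3-dichlorophenyl in place of 2-chloro-4-fluorophenyl on a carbon with a double bond to nitrogen). Within the data shown here, only one measured step bears on this change. That step, a 1.2-fold lower number from compound 1 to compound 2 (0.07 log units; within the scatter), is a swap at the same place, and it stayed within the scatter. On that single precedent, no change beyond the scatter is expected in this assay. The expected step is a 1.0-fold lower number from compound 2 to compound 3 (0.02 log units; within the scatter). Compound 3 is estimated at 28000 nM, with an expected range from 12000 nM to 60000 nM.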

Compound 3, half-maximal inhibitory concentration: 26100 nM
Beside the measured number, compound 3's estimate is 1.1-fold (0.03 log units) above it; the range from low to high includes it.
By their numbers in this assay, from the lowest: compounds 3, 2 and 1 (each within the scatter of the next).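

In this assay, 2,3-dichlorophenyl in place of 2-chloro-4-fluorophenyl gave a 1.1-fold lower number from compound 2 to compound 3 (0.05 log units; within the scatter), and the same group in place of 4-nitrophenyl gave a 1.3-fold lower number from compound 1 to compound 3 (0.12 log units; within the scatter), so all three groups on a carbon with a double bond to nitrogen now stand level with one another. Among these compounds, exchanging one fluorine for one chlorine, with the count of heavy atoms in the group unchanged at 8, therefore left the read-out within the scatter, and the single flat step known earlier now has two more beside it. Nothing available explains why this position tolerates these exchanges.

Going by these compounds, all three groups are substituted phenyl rings, so it remains open whether an amine, a carboxylic acid or a longer alkyl chain at this place would move the number beyond the scatter. On these data alone, it also remains open whether any change here, rather than in the shared core, can shift this read-out at all.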